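The source may report more compounds than this note shows. Statements on the series, on what has been measured and on what is new or still open speak of the compounds shown alone.

Series values in a functional assay on NCI-H460 cells (Homo sapiens) for inhibition, read by MTT assay, with a stated time of 24 h, tested at 1 ug/mL; on this read-out higher numbers stand for more inhibition of growth at the one concentration tested and lower numbers for less inhibition of growth:

- compound 1 `O=C(CCCCC(S)CCS)Nc1ccc(OC(F)(F)F)cc1`: 19.1%
- compound 2 `O=C(CCCCC(S)CCS)Nc1ccc([N+](=O)[O-])c(C(F)(F)F)c1`: 6.29%

Compound 2 stands at the bottom of the two measured numbers. In this assay, within the data shown here, compound 2 gives 6.29%, and the only neighbour, compound 1, gives 19.1%, a gap beyond the usual scatter.

The next compound is compound 3 `O=C(CCCCC(S)CCS)Nc1ccc([N+](=O)[O-])cc1`, with hydrogen in place of trifluoromethyl on an aromatic carbon of compound 2: hydrogen in place of trifluoromethyl on an aromatic carbon. The nitro group stays, and the rest of the structure is unchanged.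

Among the measured compounds shown here, no two measured compounds differ in one place only, so the data give no direct size for this change. For the measured compounds named here, with only two measured values, the forecast is cautious: a small upward move is expected in this assay, but not one beyond the scatter. The estimated change is a number 3.7 percentage points higher from compound 2 to compound 3 (within the scatter). The range is kept wide and reaches towards compound 1 at 19.1%. For compound 3 the expected value is 10%, with an estimated range of 2% to 24%.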

Compound 3, percent growth inhibition at one concentration: 4.64%
The estimate for compound 3 lay 5.4 percentage points above the measured number; the measured number falls inside the stated range.
By their numbers in this assay, from the lowest: compounds 3 and 2 (each within the scatter of the next); then compound 1.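

In this assay, among these compounds, the step for hydrogen in place of trifluoromethyl, on the aromatic carbon ortho to a nitro group, is a number 1.7 percentage points lower from compound 2 to compound 3 (within the scatter) and gives the first direct reading of this position: with the nitro group held, removing trifluoromethyl leaves no difference that can be told from the usual scatter. Among the compounds shown here, the change of nitro in place of trifluoromethoxy on an aromatic carbon is a number 14.5 percentage points lower from compound 1 to compound 3 (beyond the scatter) and is the only step that stands clear of the scatter, so what separates the compounds here lies in that exchange and not at the trifluoromethyl position. No measurement at hand bears on the reason for either step.

The compounds shown leave open whether any other group on the carbon ortho to a nitro group, such as chlorine, an amine or a carboxylic acid, would move the read-out at all. They also leave open whether trifluoromethoxy keeps its standing against groups such as methoxy or nitrile, since a single exchange is all that speaks for it.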